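The source may report more compounds than this note shows. Statements on the series, on what has been measured and on what is new or still open speak of the compounds shown alone.

Measured so far:
compound 1 `CCCCC#Cc1nc(NCc2cccc(Cl)c2)c2ncn([C@H]3[C@H](O)[C@H](O)[C@@H]4C[C@@H]43)c2n1` — 7.8 nM
compound 2 `CCCCC#Cc1nc(NCc2cccc(I)c2)c2ncn([C@H]3[C@H](O)[C@H](O)[C@@H]4C[C@@H]43)c2n1` — 12 nM

In an assay on CHO cells for displacement of a labelled ligand from adenosine receptor A3 (Homo sapiens), with a stated time of 60 min (on this read-out higher numbers stand for weaker inhibition and lower numbers for stronger inhibition), compound 2 gives the highest of the two numbers; its nearest neighbour is compound 1, from which the step of a 1.5-fold higher number from compound 1 to compound 2 (0.19 log units; within the scatter) is the only one measured. Compound 3 `CCCCC#Cc1nc(NCC)c2ncn([C@H]3[C@H](O)[C@H](O)[C@@H]4C[C@@H]43)c2n1` differs from compound 2 in methyl in place of 3-iodophenyl on a saturated chain carbon bound to a nitrogen on an aromatic ring. Among the compounds with values here, the one measured step exchanges substituents on the aromatic ring and does not bear on its removal; no step here covers this kind of change. The aromatic ring is nonetheless lost altogether, so a weaker inhibition is expected, with a step of about a 10-fold higher number from compound 2 to compound 3 (1.00 log units; beyond the scatter) in this assay, estimated for compound 3 as 120 nM within 25 nM to 600 nM.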

Compound 3, inhibition constant: 6.7 nM
Beside the measured number, compound 3's estimate is 18-fold (1.25 log units) above it, outside the stated range (below it).
By their numbers in this assay, from the lowest: compounds 3, 1 and 2 (each within the scatter of the next).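

In this assay methyl on the saturated chain carbon bound to a nitrogen on an aromatic ring takes the place of 3-iodophenyl (a 1.8-fold lower number from compound 2 to compound 3 (0.25 log units; within the scatter)) and of 3-chlorophenyl (a 1.2-fold lower number from compound 1 to compound 3 (0.07 log units; within the scatter)). Within the data shown here, in these compounds, then, the aromatic ring at this position can go entirely without a step beyond the scatter, whereas the earlier pair compared only two halogens on that ring. Nothing at hand accounts for this result.

Open, going by these compounds, is whether a longer chain such as butyl, or an amine or a carboxylic acid at the end of the ethyl group, stays within the scatter of these three compounds.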